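The source may report more compounds than this note shows. Statements on the series, on what has been measured and on what is new or still open speak of the compounds shown alone.

Measured so far, in an ADME assay on HEK293 cells (Homo sapiens) for cytotoxicity, read by CellTiter-Glo and resazurin assay, with a stated time of 72 h; on this read-out higher numbers stand for an effect only at larger amounts of compound and lower numbers for an effect already at smaller amounts:

Compound 1, `CC(C)N(Cc1cccc(OCCCCCC(=O)O)c1)C(=O)c1ccc(-c2ccncc2)cc1`, gives > 26000 nM, which is a limit of this assay and not a number.
Compound 2, `CC(C)N(Cc1cccc(OCCCCCC(=O)O)c1)C(=O)c1ccc(-c2ccsc2)cc1`, gives > 26000 nM, again a limit of this assay.
Compound 3, `CCOC(=O)CCCCCOc1cccc(CN(C(=O)c2ccc(-c3ccncc3)cc2)C(C)C)c1`, gives > 26000 nM, likewise a limit of this assay.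

Compound 3 therefore stands at the limit, as do the other two compounds shown; that is the whole of what is known (the limit of > 26000 nM in this assay, at which 3 of the 3 values shown sit). Compound 4, `CCOC(=O)CCCCCOc1cccc(CN(C(=O)c2ccc(-c3ccc(C(C)=O)s3)cc2)C(C)C)c1`, is not yet measured. It differs from compound 3 in one place: 5-acetylthiophen-2-yl in place of pyridin-4-yl on an aromatic carbon. Within the data shown here, two measured steps bear on it. The first, a step that the two limits leave unreadable from compound 1 to compound 2, exchanges one aromatic ring for another on the same carbon, but its size cannot be read, since both compounds sit at the limit. The second, a step that the two limits leave unreadable from compound 1 to compound 3, is equally unreadable for the same reason. Among the measured compounds shown here, no measured step gives a readable size, so no step beyond the scatter in this assay can be expected either way. For compound 4 the estimate is 26000 nM, expected to lie between 9000 nM and 80000 nM. The expected step is a number no higher from compound 3 to compound 4 (the limit leaves the size open), which would most likely again appear only as a limit.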

Compound 4, half-maximal effective concentration: > 26000 nM
Compound 4 was reported as a limit; the forecaster's own chance of this, stated with the estimate: 75%; the middle value lies on the limit itself.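

The step between compound 3 and compound 4 cannot be read, since both are reported only as limits in this assay: the limit of > 26000 nM in this assay, at which 4 of the 4 values shown sit. The compounds shown leave open how far each lies from that limit, and which change, if any, would give a readable value in this assay.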